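The source may report more compounds than this note shows. Statements on the series, on what has been measured and on what is new or still open speak of the compounds shown alone.

Measured so far, in a functional assay on NCI-H226 cells (Homo sapiens) for inhibition, read by sulforhodamine B assay, with a stated time of 48 h; on this read-out higher numbers stand for weaker inhibition of growth and lower numbers for stronger inhibition of growth:
- compound 1 `COc1cc(-c2cc(/C=C/C(=O)c3ccc(Cl)c(Cl)c3)[nH]n2)cc(OC)c1OC`: > 100000 nM, which is a limit of the assay rather than a number.
- compound 2 `COc1ccc(C(=O)/C=C/c2cc(-c3cc(OC)c(OC)c(OC)c3)n[nH]2)cc1OC`: 3320 nM.
- compound 3 `COc1cc(-c2cc(/C=C/C(=O)c3ccc(F)c(F)c3)[nH]n2)cc(OC)c1OC`: 15800 nM.

Among the two actual numbers, compound 2 stands lowest; the step of a 4.8-fold higher number from compound 2 to compound 3 (0.68 log units; beyond the scatter) separates it from its nearest neighbour. Compound 4 `COc1cc(C(=O)/C=C/c2cc(-c3cc(OC)c(OC)c(OC)c3)n[nH]2)cc(OC)c1OC` arises from compound 2 by methoxy in place of hydrogen on an aromatic carbon. Every measured step swaps the whole ring attached to the carbonyl carbon: an at least 30-fold lower number from compound 1 to compound 2 (1.47 log units; beyond the scatter), an at least 6.3-fold lower number from compound 1 to compound 3 (0.80 log units; beyond the scatter) and a 4.8-fold higher number from compound 2 to compound 3 (0.68 log units; beyond the scatter). None of them adds a single group to an already substituted ring, so none bears directly on this change. The expected step is therefore small, a 1.3-fold lower number from compound 2 to compound 4 (0.12 log units; within the scatter), with direction uncertain. Compound 4 is estimated at 2500 nM, within a range from 600 nM to 12000 nM.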

Compound 4, concentration for total growth inhibition: 3050 nM
For compound 4 the middle estimate is 1.2-fold (0.09 log units) below the measured one; low and high end bracket the measured number.
By their numbers in this assay, from the lowest: compounds 4 and 2 (each within the scatter of the next); then compound 3. At a limit, above all of these: compound 1.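

In this assay, methoxy in place of hydrogen on this aromatic carbon, ortho to a methoxy group, gives a 1.1-fold lower number from compound 2 to compound 4 (0.04 log units; within the scatter) as its step. Unlike the swaps of the whole ring among the earlier compounds, this single added group causes no change that can be told from the scatter. Nothing shown here offers a reason for this result.

Going by these compounds, whether this position accepts other groups stays open. An amine, a carboxylic acid or a longer chain such as butoxy on the same carbon could behave quite differently from methoxy.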